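Moving a trifluoromethyl group on the benzoyl ring

The compounds below may be only part of what the source reports. "The series", "measured", "known", "first", "only" and "open" are said of these compounds alone.

Measured compounds:
Compound 1, `O=C(c1ccccc1C(F)(F)F)N(/N=N/c1ccc([N+](=O)[O-])cc1Br)c1ccc([N+](=O)[O-])cc1Br`: 13300 nM
Compound 2, `O=C(c1cccc(C(F)(F)F)c1)N(/N=N/c1ccc([N+](=O)[O-])cc1Br)c1ccc([N+](=O)[O-])cc1Br`: 1120 nM
Compound 3, `O=C(c1ccccc1C(F)(F)F)N(/N=N/c1ccc([N+](=O)[O-])cc1C(F)(F)F)c1ccc([N+](=O)[O-])cc1C(F)(F)F`: 5350 nM

These values come from a functional assay on HeLa cells (Homo sapiens) for cytotoxicity, read by MTT assay, with a stated time of 72 h; a higher number here means a weaker inhibitor, a lower number a stronger inhibitor. Compound 1 and compound 2 differ only in the acyl part of the amide: 3-(trifluoromethyl)phenyl in place of 2-(trifluoromethyl)phenyl on a carbonyl carbon. That single change gave a 12-fold lower number from compound 1 to compound 2 (1.07 log units; beyond the scatter).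

Compound 3 shares the acyl group of compound 1 but has a different core; the difference between the two cores is not broken down here. In this assay compound 3 sits between the other two, with a value above compound 2 and below compound 1.

Compound 4, `O=C(c1cccc(C(F)(F)F)c1)N(/N=N/c1ccc([N+](=O)[O-])cc1C(F)(F)F)c1ccc([N+](=O)[O-])cc1C(F)(F)F`, has not yet been measured. It differs from compound 3 by the same change: 3-(trifluoromethyl)phenyl in place of 2-(trifluoromethyl)phenyl on a carbonyl carbon. Because the change from compound 1 to compound 2 produced a 12-fold lower number from compound 1 to compound 2 (1.07 log units; beyond the scatter), a step of similar size is expected here, namely an 8.9-fold lower number from compound 3 to compound 4 (0.95 log units; beyond the scatter). Compound 4 is therefore expected to give about 600 nM, most likely between 200 nM and 2000 nM.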

Compound 4, half-maximal inhibitory concentration: 750 nM
For compound 4 the middle estimate is 1.3-fold (0.10 log units) below the measured one; the measured number falls inside the stated range.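

In this assay, replacing 2-(trifluoromethyl)phenyl with 3-(trifluoromethyl)phenyl gave a 7.1-fold lower number from compound 3 to compound 4 (0.85 log units; beyond the scatter), so the same change lowered the number on a second core as well. The two steps agree within the scatter, so in these compounds the change carried over from one core to the other with much the same size: the same change on two cores in this assay, a 12-fold lower number (1.07 log units; beyond the scatter) from compound 1 to compound 2 and a 7.1-fold lower number (0.85 log units; beyond the scatter) from compound 3 to compound 4, 1.7-fold (0.22 log units) apart, within the scatter of two such steps

Among these compounds, this rests on only two cores in a single assay, and it shows neither why the change lowers the number nor that it would do so on any further core.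

The compounds shown leave open whether a similar step would appear with a different group, such as a nitrile or a carboxylic acid, in place of the trifluoromethyl group on the acyl part.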